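A piperazine side chain replaces a triazole

A few compounds are considered here, and "the series" means these few. Any claim that something is new, unique, unknown or untested is made for them only; others in the source may bear on it.

In a toxicity assay on HEK-293T cells (Homo sapiens) for cytotoxicity, read by MTT assay, with a stated time of 72 h (on this read-out lower numbers stand for stronger inhibition and higher numbers for weaker inhibition), compound 1 (`O=C1c2c[n+]([O-])c3ccccc3c2C(=O)c2c1c1ccccc1n2CCCCn1ccnc1`) gives 280 nM, while compound 2 (`O=C1c2c[n+]([O-])c3ccccc3c2C(=O)c2c1c1ccccc1n2Cc1cn(CC(O)CO)nn1`) gives 760 nM, the higher of the two numbers. Compound 3 (`O=C1c2c[n+]([O-])c3ccccc3c2C(=O)c2c1c1ccccc1n2CCCCN1CCNCC1`) has 3-(piperazin-1-yl)propyl in place of 1-(2,3-dihydroxypropyl)-1H-1,2,3-triazol-4-yl on a saturated chain carbon bound to an aromatic nitrogen. Within the data shown here, the only measured step, a 2.7-fold higher number from compound 1 to compound 2 (0.43 log units; beyond the scatter), brought in that same triazole group in place of 3-(1H-imidazol-1-yl)propyl, another propyl group carrying a ring. The expected change in this assay is therefore a modest one towards a lower number, a 2.5-fold lower number from compound 2 to compound 3 (0.40 log units; beyond the scatter). Compound 3 is estimated at 300 nM, within a range of 100 nM to 900 nM.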

Compound 3, half-maximal inhibitory concentration: 760 nM
Compound 3: the middle estimate sits 2.5-fold (0.40 log units) below what was measured; the range from low to high includes it.
By their numbers in this assay, from the lowest: compound 1; then compounds 2 and 3 (each within the scatter of the next).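

In this assay, the side chains of compound 2 and compound 3 end in very different rings, one five-membered and aromatic, the other six-membered and non-aromatic, yet the change gives no change at the digits printed from compound 2 to compound 3 (within the scatter) and no separation. With the chain kept, piperazin-1-yl in place of 1H-imidazol-1-yl gives a 2.7-fold higher number from compound 1 to compound 3 (0.43 log units; beyond the scatter) at this position, so the end ring alone can move the number, and compound 1 stays lowest. Nothing available explains either result. As far as these compounds go, whether an open-chain dimethylamino group or a carboxylic acid at the end of this chain would fall nearer compound 1 remains open, as does the effect of a longer chain.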